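The compounds below may be only part of what the source reports. "The series", "measured", "known", "first", "only" and "open" are said of these compounds alone.

Among the three compounds measured, compound 3 `CCCCCCCCCCCCCCCCCCCc1nc(N(C)C)c(C)c(C)c1O` stands lowest in a functional assay on cells (Lymphocyte, Homo sapiens), read by trypan blue exclusion, with a stated time of 16 h, tested at 2.5 uM (a higher number here means a stronger effect of the compound at the concentration tested, a lower number a weaker effect), where compound 3 gives 76%. Compound 1 `CCCCCCCCCCCCCCCCc1nc(N2CCC2)c(C)c(C)c1O` gives 87%, and compound 2 `Cc1c(N(C)C)nc(CCCCCCCCCCO)c(O)c1C` gives 87%, each separated from compound 3 by a gap beyond the scatter. Among the compounds with values here, the one measured step that reaches the far end of the long chain, a number 11 percentage points lower from compound 2 to compound 3 (beyond the scatter), puts nonyl in place of hydroxy and so alters more than chain length alone. Compound 4 `CCCCCCCCCCCCCCCCc1nc(N(C)C)c(C)c(C)c1O` differs from compound 3 by hydrogen in place of propyl on a saturated chain carbon, ten or more bonds along the chain from an aromatic carbon; the chain is shortened and nothing else moves. Within the data shown here, no measured step shortens a chain by itself, so the expectation rests on compound 3 and on compound 1, whose chain is already the shortened one and which gives 87%. Compound 4 is therefore expected to land between these, with the step of a number 7 percentage points higher from compound 3 to compound 4 (within the scatter) expected to be modest and upward. The estimate for compound 4 in this assay is 83%, within a range from 72% to 93%.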

Compound 4, a percentage reported as activity, at one concentration (the size of the read-out at that concentration, not a potency): 92%
Compound 4: the middle estimate sits 9 percentage points below what was measured; low and high end bracket the measured number.
By their numbers in this assay, from the lowest: compound 3; then compounds 1, 2 and 4 (each within the scatter of the next).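

In this assay, within the data shown here, the step of a number 16 percentage points higher from compound 3 to compound 4 (beyond the scatter) is the one measured change that alters chain length alone, with hydrogen in place of propyl on a saturated chain carbon, ten or more bonds along the chain from an aromatic carbon, and it shows that a change this far out on the chain can by itself move the read-out beyond the scatter. The other two steps separate nothing: a number 5 percentage points higher from compound 2 to compound 4 (within the scatter) replaces hydroxy with hexyl, and a number 5 percentage points higher from compound 1 to compound 4 (within the scatter) puts dimethylamino in place of azetidin-1-yl on an aromatic carbon. Nothing available explains the drop seen with the longer chain of compound 3.

From the compounds shown here alone, it remains open whether the read-out falls gradually or abruptly as the chain grows from that of compound 4 to that of compound 3. Also open, going by these compounds, is how a carboxylic acid or an amine at the chain end would compare with hydroxy.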